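The source may report more compounds than this note shows. Statements on the series, on what has been measured and on what is new or still open speak of the compounds shown alone.

Within the data shown here, in a functional assay on Huh-7 cells (Homo sapiens) for inhibition, read by CCK-8 assay, with a stated time of 72 h (on this read-out higher numbers stand for weaker inhibition of growth and lower numbers for stronger inhibition of growth), compound 1 (`C#Cc1cccc(Nc2ncnc3cc(OC)c(OCCCCCCCN/C(=N\C#N)Nc4cccnc4)cc23)c1`) gives 9.94 nM, the higher of the two numbers known so far, and compound 2 (`C#Cc1cccc(Nc2ncnc3cc(OC)c(OCCCCCN/C(=N\C#N)Nc4ccncc4)cc23)c1`) gives 1.64 nM, a gap beyond the scatter. Compound 3 (`C#Cc1cccc(Nc2ncnc3cc(OC)c(OCCCCCCCN/C(=N\C#N)Nc4ccncc4)cc23)c1`) has not yet been measured. It differs from compound 1 by pyridin-4-yl in place of pyridin-3-yl on an amine nitrogen, with pyridin-4-yl in place of pyridin-3-yl on an amine nitrogen. Compound 2 also carries pyridin-4-yl and gives 1.64 nM, but it differs from compound 1 elsewhere too. Only a moderate drop is therefore expected, an estimated 2.5-fold lower number from compound 1 to compound 3 (0.40 log units; beyond the scatter). For compound 3 the expected value is 4 nM, with an estimated range of 1.5 nM to 11 nM.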

Compound 3, concentration for 50% growth inhibition: 1.81 nM
Estimate against measurement, compound 3: 2.2-fold (0.34 log units) above, within the range that was stated.
By their numbers in this assay, from the lowest: compounds 2 and 3 (each within the scatter of the next); then compound 1.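

With the rest of the structure unchanged, pyridin-4-yl in place of pyridin-3-yl on the amine nitrogen gives a 5.5-fold lower number from compound 1 to compound 3 (0.74 log units; beyond the scatter) in this assay, so the place of the ring nitrogen alone separates these two compounds. With pyridin-4-yl on that amine nitrogen, compound 3 at 1.81 nM and compound 2 at 1.64 nM lie within the scatter of each other. No measurement here explains the effect of this change. Open, going by these compounds, is how pyridin-2-yl or a plain phenyl would behave on the same amine nitrogen, and whether a longer chain would keep the values of compound 2 and compound 3.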